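Ether substituent variation on the shared core

The source may hold more compounds than are shown below. What is called first, only, known or untested is meant among the compounds shown, and "the series" means these compounds.

Measured compounds:
compound 1: `Cc1nn(-c2ncnc3nc[nH]c23)c2c1C(OCC(=O)c1ccc(F)cc1)CC(=O)N2` — 3 nM
compound 2: `Cc1nn(-c2ncnc3nc[nH]c23)c2c1C(OC1CCCC1)CC(=O)N2` — 2 nM
compound 3: `Cc1nn(-c2ncnc3nc[nH]c23)c2c1C(OCc1ccc(F)cc1)CC(=O)N2` — 1 nM

All three values come from a functional assay on HEK293 cells for agonist activity at G-protein coupled receptor 39 (Homo sapiens), read by scintillation proximity assay and inositol phosphate accumulation, with a stated time of 75 min, in the presence of a further agent that is not named here (on this read-out higher numbers stand for an effect only at larger amounts of compound and lower numbers for an effect already at smaller amounts), and sit close together. Compound 2 stands second highest of the three numbers, nearest to compound 1 and furthest from compound 3, yet both of its steps lie within the scatter: a 1.5-fold lower number from compound 1 to compound 2 (0.18 log units; within the scatter) and a 2.0-fold lower number from compound 2 to compound 3 (0.30 log units; within the scatter). Going by the values given here, the only step reaching beyond the scatter is the modest one a 3.0-fold lower number from compound 1 to compound 3 (0.48 log units; beyond the scatter).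

Compound 4, `Cc1nn(-c2ncnc3nc[nH]c23)c2c1C(OCCn1cccn1)CC(=O)N2`, differs from compound 2 in one place: 2-(1H-pyrazol-1-yl)ethyl in place of cyclopentyl on an oxygen on a saturated carbon. Among the compounds with values here, the steps that bear on this change are the two that also swap the group on the oxygen on a saturated carbon, from compound 1 to compound 2 and from compound 2 to compound 3, and both were small. Within the data shown here, no measured compound carries a pyrazole-containing group, so the comparison rests on those two steps alone. A step of a 1.5-fold higher number from compound 2 to compound 4 (0.18 log units; within the scatter) is therefore expected for compound 4, within the scatter in either direction. Compound 4 is estimated at 3 nM in this assay, with a range of 1 nM to 10 nM.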

Compound 4, half-maximal effective concentration: 16 nM
Compound 4: the middle estimate sits 5.3-fold (0.73 log units) below what was measured, and the stated range ends below it.
By their numbers in this assay, from the lowest: compounds 3, 2 and 1 (each within the scatter of the next, the first and the last beyond it); then compound 4.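

In this assay the group on this oxygen on a saturated carbon proves able to move the number beyond the scatter, since 2-(1H-pyrazol-1-yl)ethyl in place of cyclopentyl gives an 8.0-fold higher number from compound 2 to compound 4 (0.90 log units; beyond the scatter), whereas the two earlier steps from cyclopentyl lay within it. The same group also stands apart from the two other ethers, with a 16-fold higher number from compound 3 to compound 4 (1.20 log units; beyond the scatter) and a 5.3-fold higher number from compound 1 to compound 4 (0.73 log units; beyond the scatter), so all three new steps run the same way, beyond the scatter. Nothing available accounts for this shift.

Going by these compounds, whether the shift goes with the pyrazole ring itself or with the ethyl link that carries it stays open. A phenyl ring on the same ethyl chain, a pyrazole on a longer chain, or a simple amine at the end of the chain would separate these readings.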